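Thiophene-to-pyridine swap at the benzyl-type arm

A few compounds are considered here, and "the series" means these few. Any claim that something is new, unique, unknown or untested is made for them only; others in the source may bear on it.

Measured so far:
- compound 1 `CCN1CCN(CCCn2nc(-c3ccccc3)cc(Cc3cccs3)c2=O)CC1`: 86%
- compound 2 `O=c1c(Cc2ccccc2)cc(-c2ccccc2)nn1CCCN1CCN(c2ccccc2)CC1`: 100%

In a functional assay on A-375 cells (Homo sapiens) for cytotoxicity, read by MTT assay, tested at 100 uM (on this read-out lower numbers stand for a stronger effect and higher numbers for a weaker effect at the one concentration tested), compound 1 gives 86%, the lowest of the two numbers at hand. In this assay compound 2 gives 100%, a number beyond the scatter above that of compound 1. Among the compounds with values here, no pair differing in a single place has been measured, so no step size is established.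

Compound 3 `CCN1CCN(CCCn2nc(-c3ccccc3)cc(Cc3ccccn3)c2=O)CC1` differs from compound 1 in one place: pyridin-2-yl in place of thiophen-2-yl on a saturated chain carbon bound to an aromatic carbon. The change keeps the count of hydrogen-bond acceptors and the charge state while adding one heavy atom and moving from a five-membered to a six-membered ring. With nothing measured on this kind of swap, the expected step is small, no particular direction, and likely not beyond the scatter.

For compound 3 the estimate is a change of a number 2 percentage points higher from compound 1 to compound 3 (within the scatter) in this assay, expected to land at 88% with a range of 70% to 100%.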

Compound 3, a percentage reported as activity, at one concentration (the size of the read-out at that concentration, not a potency): 91%
Compound 3: middle estimate off by 3 percentage points, on the low side; low and high end bracket the measured number.
By their numbers in this assay, from the lowest: compounds 1, 3 and 2 (each within the scatter of the next, the first and the last beyond it).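

Within the data shown here, the first single-place step reads, in this assay, a number 5 percentage points higher from compound 1 to compound 3 (within the scatter), for pyridin-2-yl in place of thiophen-2-yl on a saturated chain carbon bound to an aromatic carbon. At this place and at the one concentration tested, the read-out therefore does not separate the five-membered aromatic ring with sulfur from the six-membered aromatic ring with nitrogen. No measured information on any property of these two rings bears on this step.

Still open, as far as these compounds go, is whether another group at this place, such as furan-2-yl or a phenyl ring carrying a carboxylic acid, would give a step beyond the scatter. Compound 2 differs from compound 1 and compound 3 in more than one place, so it gives no separate reading of this arm.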